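A few compounds are considered here, and "the series" means these few. Any claim that something is new, unique, unknown or untested is made for them only; others in the source may bear on it.

Series notes, one change at a time.

For the measured compounds named here, compound 1 `O=c1[nH]/c(=N\OCCCc2ccc(Br)cc2)ccn1[C@@H]1O[C@H](COP(=O)(O)OP(=O)(O)OP(=O)(O)O)[C@@H](O)[C@H]1O` gives 141 nM in a functional assay on 1321-N1 cells for agonist activity at P2Y purinoceptor 4 (Homo sapiens), read by scintillation counting and inositol phosphate accumulation (a higher number here means that more compound is needed for the effect, a lower number that less compound is needed), the second highest of the three numbers so far. Compound 2 `COc1ccc(CCCO/N=c2/ccn([C@@H]3O[C@H](COP(=O)(O)OP(=O)(O)OP(=O)(O)O)[C@@H](O)[C@H]3O)c(=O)[nH]2)cc1` gives 23 nM; compound 3 `O=c1[nH]/c(=N\OCCCc2cccnc2)ccn1[C@@H]1O[C@H](COP(=O)(O)OP(=O)(O)OP(=O)(O)O)[C@@H](O)[C@H]1O` gives 300 nM. The step from compound 1 to compound 2 ran a 6.1-fold lower number from compound 1 to compound 2 (0.79 log units; beyond the scatter), and the step from compound 1 to compound 3 ran a 2.1-fold higher number from compound 1 to compound 3 (0.33 log units; beyond the scatter).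

Compound 4 `O=c1[nH]/c(=N\OCCCc2ccsc2)ccn1[C@@H]1O[C@H](COP(=O)(O)OP(=O)(O)OP(=O)(O)O)[C@@H](O)[C@H]1O` differs from compound 1 in one place: thiophen-3-yl in place of 4-bromophenyl on a saturated chain carbon, three bonds along the chain from an oxygen. Going by the values given here, the nearest precedent is the step of a 2.1-fold higher number from compound 1 to compound 3 (0.33 log units; beyond the scatter), where a heteroaromatic ring also replaced the 4-bromophenyl; a modest rise is therefore expected for compound 4, of about a 1.8-fold higher number from compound 1 to compound 4 (0.27 log units; within the scatter). Compound 4 is estimated at 260 nM, with a range from 100 nM to 700 nM, pending measurement.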

Compound 4, half-maximal effective concentration: 20 nM
Compound 4: the middle estimate sits 13-fold (1.11 log units) above what was measured, outside the stated range (below it).
By their numbers in this assay, from the lowest: compounds 4 and 2 (each within the scatter of the next); then compound 1; then compound 3.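

At this place, a heteroaromatic ring in place of 4-bromophenyl does not necessarily raise the number: thiophen-3-yl gives a 7.1-fold lower number from compound 1 to compound 4 (0.85 log units; beyond the scatter), whereas pyridin-3-yl in compound 3 went the other way. The identity of the ring matters, with a 15-fold lower number from compound 3 to compound 4 (1.18 log units; beyond the scatter), while thiophen-3-yl and 4-methoxyphenyl cannot be separated, at a 1.2-fold lower number from compound 2 to compound 4 (0.06 log units; within the scatter). No measurement available here accounts for these differences.

Open, as far as these compounds go, is whether thiophen-2-yl or furan-3-yl matches thiophen-3-yl here. Also open, from the compounds shown here alone, is how an amine or carboxylic acid on the ring would fare.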